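From chloro to methoxy on an aromatic carbon

The source may report more compounds than this note shows. Statements on the series, on what has been measured and on what is new or still open speak of the compounds shown alone.

- compound 1 `COc1ccc(Nc2nc(N)c(C(=O)c3ccc(OC)c(OC)c3)s2)cc1`: 71 nM
- compound 2 `COc1cc(C(=O)c2sc(Nc3ccc(Cl)cc3)nc2N)cc(OC)c1OC`: 420 nM

In a functional assay on FM3A cells (Mus musculus) for antiproliferative activity, read by cell counting, with a stated time of 2 days (a higher number here means a weaker inhibitor, a lower number a stronger inhibitor), compound 2 gives 420 nM, the higher of the two numbers, and its gap to the other compound lies beyond the scatter. Compound 3 `COc1ccc(Nc2nc(N)c(C(=O)c3cc(OC)c(OC)c(OC)c3)s2)cc1` has not yet been measured. It departs from compound 2 by methoxy in place of chloro on an aromatic carbon, para to a large group: methoxy in place of chloro on an aromatic carbon. The same difference reads 4-chlorophenyl to 4-methoxyphenyl. Among the compounds with values here, no measured pair shows this change on its own, so its size remains a judgement. Within the data shown here, the only lower reference is compound 1 at 71 nM, and on that basis a downward step beyond the scatter is expected in this assay. The expected change is a 3.5-fold lower number from compound 2 to compound 3 (0.54 log units; beyond the scatter). For compound 3 the estimated value is 120 nM, with an expected range from 40 nM to 350 nM.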

Compound 3, half-maximal inhibitory concentration: 2200 nM
The estimate for compound 3 lay 18-fold (1.26 log units) below the measured number; the measured number lies above the stated range.
By their numbers in this assay, from the lowest: compound 1; then compound 2; then compound 3.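

In this assay, methoxy in place of chloro on an aromatic carbon, para to a large group, goes with a 5.2-fold higher number from compound 2 to compound 3 (0.72 log units; beyond the scatter), so in this pair the chloro compound is the stronger inhibitor. Methoxy in place of hydrogen on an aromatic carbon elsewhere in the molecule goes with a 31-fold higher number from compound 1 to compound 3 (1.49 log units; beyond the scatter), a large step that shows this second site also responds strongly to a single added group. Nothing measured here explains either step.

The compounds shown leave open how an amine or a hydroxy group on the aromatic carbon that carries chloro or methoxy would compare with those two groups. They also leave open whether methoxy in place of hydrogen brings a step of similar size when chloro replaces methoxy at the first site.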